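The compounds below may be only part of what the source reports. "The series", "measured", "known", "first", "only" and "open" are said of these compounds alone.

Measured compounds in an ADME assay on HCT-116 cells (Homo sapiens) for cytotoxicity, read by CellTiter-Glo, with a stated time of 72 h; a lower number here means a stronger inhibitor, a higher number a weaker inhibitor:

- compound 1 `CC1CCN(C2CCN(S(=O)(=O)c3ccc(F)cc3F)CC2)CC1` gives > 5000 nM, a limit of the assay.
- compound 2 `CC1CCN(C2CCN(S(=O)(=O)c3nccn3C)CC2)CC1` gives > 10000 nM, a limit of the assay.
- compound 3 `CC1CCN(C2CCN(S(=O)(=O)c3cccc(C(F)(F)F)c3)CC2)CC1` gives > 5000 nM, a limit of the assay.

Compound 3 stands at the lower limit of the set: its value in this assay is a limit and not a number. The other two values shown are limits as well, two of the three sitting at the limit of > 5000 nM in this assay, at which 2 of the 3 values shown sit, and one at the limit of > 10000 nM in this assay, at which 1 of the 3 values shown sits. Within the data shown here, the only step between measured compounds, a step that the two limits leave unreadable from compound 1 to compound 2, cannot be read because both ends are limits, so no measured step gives a size.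

Compound 4 `CC1CCN(C2CCN(S(=O)(=O)c3cccc(Cl)c3)CC2)CC1` differs from compound 3 in one place: chloro in place of trifluoromethyl on an aromatic carbon. Nothing measured bears on this change directly, and the whole series has so far stayed at or past the limits of this assay. The expectation is therefore that compound 4 also shows no potency beyond the scatter, with the step that the limit leaves unreadable from compound 3 to compound 4 expected to be unreadable in practice. Compound 4 is estimated at 8000 nM, in the range from 3000 nM to 25000 nM, most likely reported again only as a limit.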

Compound 4, half-maximal inhibitory concentration: > 5000 nM
Compound 4 gave a limit, no number; the forecaster's own chance of this, stated with the estimate: 85%; the middle value is on the limit's open side.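

In this assay compound 4 returns only a limit, as do compound 1, compound 2 and compound 3, so the steps from those three compounds to compound 4 cannot be read. The compounds shown leave open how far any group on the sulfonyl sulfur shifts the half-maximal inhibitory concentration: none of the four gives a number.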